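The source may hold more compounds than are shown below. What is called first, only, known or untested is meant among the compounds shown, and "the series" means these compounds.

Measured so far in a functional assay on HCT-116 cells (Homo sapiens) for cytotoxicity, read by MTT assay, with a stated time of 72 h; on this read-out higher numbers stand for weaker inhibition and lower numbers for stronger inhibition:
Compound 1 `O=C(NCc1ccc(F)cc1)c1nc(Br)c2cccnc2c1NCc1ccc(F)cc1`: compound 1 gives only a limit of the assay, > 20000 nM.
Compound 2 `N[C@H]1CC[C@H](NC(=O)c2nc(Br)c3cccnc3c2NCc2ccc(F)cc2)CC1`: compound 2 gives 6400 nM.
Compound 3 `N[C@H]1CC[C@H](Nc2c(C(=O)NCc3cccs3)nc(Br)c3cccnc23)CC1`: for compound 3 the result is "not determined" (no result reported).

Compound 1 has no single number in this assay; it sits at the limit of > 20000 nM in this assay, at which 1 of the 3 values shown sits, the only such entry among the three, and compound 3 brings no number at all. Among the compounds with values here, the one measured step, an at least 3.1-fold lower number from compound 1 to compound 2 (0.49 log units; beyond the scatter), concerns the amide-type nitrogen and shows that the core of compound 1 can reach a measurable number when that substituent is exchanged.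

Compound 4 `COC(=O)CNc1c(C(=O)NCc2ccc(F)cc2)nc(Br)c2cccnc12` differs from compound 1 at a different place: methoxycarbonyl in place of 4-fluorophenyl on a saturated chain carbon bound to a nitrogen on an aromatic ring. Within the data shown here, no measured step touches this position, so the step from compound 1 to compound 2 does not bear on it directly; it gives no guide to direction or size for a change on the nitrogen bound to the aromatic ring. With compound 1 known only as a limit, no step beyond the scatter is expected, and the estimated step that the limit leaves unreadable from compound 1 to compound 4 is set near zero. Compound 4 is therefore expected to give about 25000 nM in this assay, within 8000 nM to 80000 nM, with a substantial chance that again only a limit is returned.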

Compound 4, half-maximal inhibitory concentration: > 10000 nM
Compound 4: no number, only a limit; the forecaster's own chance of this, stated with the estimate: 60%; the middle value lies beyond the limit too.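

In this assay, compound 1 and compound 4 each return only a limit, so no step can be read between them. The compounds shown leave open whether methoxycarbonyl in place of 4-fluorophenyl on a saturated chain carbon bound to a nitrogen on an aromatic ring changes the number in either direction.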